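The source may report more compounds than this note shows. Statements on the series, on what has been measured and on what is new or still open speak of the compounds shown alone.

Measured in a functional assay on NCI-H1975 cells (Homo sapiens) for inhibition, read by MTT assay, with a stated time of 72 h; a higher number here means a weaker inhibitor, a lower number a stronger inhibitor:
compound 1 `O=C(CSc1nc(Nc2ccccc2)c2ccccc2n1)Nc1ccccc1F` gives 9350 nM
compound 2 `O=C(CSc1nc(Nc2ccccc2)c2ccccc2n1)Nc1ccccc1Cl` gives 9610 nM
compound 3 `CCc1cccc(NC(=O)CSc2nc(Nc3ccccc3)c3ccccc3n2)c1` gives 12000 nM

Compound 3 carries the highest of the three numbers, but its gaps to the others, a 1.3-fold higher number from compound 1 to compound 3 (0.11 log units; within the scatter) and a 1.2-fold higher number from compound 2 to compound 3 (0.10 log units; within the scatter), both lie within the scatter, so the three compounds cannot be told apart. Compound 4 `C=CC(=O)Nc1cccc(NC(=O)CSc2nc(Nc3ccccc3)c3ccccc3n2)c1` differs from compound 3 by (vinylcarbonyl)amino in place of ethyl on an aromatic carbon. The measured steps that bear on this are the exchanges of the aryl group on the amide nitrogen, a 1.3-fold higher number from compound 1 to compound 3 (0.11 log units; within the scatter) and a 1.2-fold higher number from compound 2 to compound 3 (0.10 log units; within the scatter), and the halogen swap a 1.0-fold higher number from compound 1 to compound 2 (0.01 log units; within the scatter); all three stayed within the scatter. Among the compounds with values here, no measured compound carries anything resembling the entering (vinylcarbonyl)amino group, so its effect is untested. The expected step is therefore small, a 1.7-fold lower number from compound 3 to compound 4 (0.23 log units; within the scatter), with a wide range. Compound 4 is estimated at 7000 nM, between 1500 nM and 25000 nM.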

Compound 4, half-maximal inhibitory concentration: 8120 nM
The estimate for compound 4 lay 1.2-fold (0.06 log units) below the measured number; the measured number falls inside the stated range.
By their numbers in this assay, from the lowest: compounds 4, 1, 2 and 3 (each within the scatter of the next).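

Replacing ethyl with (vinylcarbonyl)amino on the aromatic carbon is a much bigger change than the earlier swaps, yet in this assay the number stays within the scatter (a 1.5-fold lower number from compound 3 to compound 4 (0.17 log units; within the scatter)). The steps from the two halogen-bearing compounds, (a 1.2-fold lower number from compound 2 to compound 4 (0.07 log units; within the scatter)) and (a 1.2-fold lower number from compound 1 to compound 4 (0.06 log units; within the scatter)), also stay within the scatter, so this position has so far tolerated very different groups without a readable change. No evidence is available to explain this result.

As far as these compounds go, whether a propanoylamino group, which lacks the vinyl double bond, or a plain amine at this place would read the same remains open. So does whether any change to the shared core would move the number beyond the scatter.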